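A few compounds are considered here, and "the series" means these few. Any claim that something is new, unique, unknown or untested is made for them only; others in the source may bear on it.

Compound 1 `Oc1ccccc1-c1cc(-c2ccccc2C(F)(F)F)cc(-c2ccccc2O)n1` carries two 2-hydroxyphenyl groups and a 2-(trifluoromethyl)phenyl group on a shared core. In a functional assay on HeLa cells (Homo sapiens) for inhibition (a lower number here means a stronger inhibitor, a higher number a weaker inhibitor), compound 1 gives 5800 nM. Compound 2 `Oc1ccccc1-c1cc(-c2cccc(C(F)(F)F)c2)cc(-c2ccccc2O)n1` differs from compound 1 by 3-(trifluoromethyl)phenyl in place of 2-(trifluoromethyl)phenyl on an aromatic carbon. For compound 2 this assay reports only a limit, > 50000 nM, and no number. The step is an at least 8.6-fold higher number from compound 1 to compound 2 (0.93 log units; beyond the scatter); its size cannot be told exactly, since one of the two values is the limit of > 50000 nM in this assay, at which 1 of the 3 values shown sits.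

Compound 3 `Oc1ccc(-c2cc(-c3ccccc3C(F)(F)F)cc(-c3ccccc3O)n2)cc1` differs from compound 1 by 4-hydroxyphenyl in place of 2-hydroxyphenyl on an aromatic carbon. In this assay compound 3 gives 16500 nM, which is a 2.8-fold higher number from compound 1 to compound 3 (0.45 log units; beyond the scatter).

Compound 4 `Oc1ccc(-c2cc(-c3cccc(C(F)(F)F)c3)cc(-c3ccccc3O)n2)cc1` has not been measured. It differs from compound 3 by 3-(trifluoromethyl)phenyl in place of 2-(trifluoromethyl)phenyl on an aromatic carbon. Going by the values given here, this is the same kind of change as the one from compound 1 to compound 2, not the same change: there the place was meta to two 2-hydroxyphenyl groups, here it is meta to a 2-hydroxyphenyl group and meta to a 4-hydroxyphenyl group, since the two cores differ by 4-hydroxyphenyl in place of 2-hydroxyphenyl on an aromatic carbon.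

Compound 4 is expected to give a weaker result than compound 3, a step of a 7.3-fold higher number from compound 3 to compound 4 (0.86 log units; beyond the scatter) in this assay, resting on the step from compound 1 to compound 2, which was an at least 8.6-fold higher number from compound 1 to compound 2 (0.93 log units; beyond the scatter). Compound 4 is therefore estimated at 120000 nM, with a range from 40000 nM to 400000 nM, and a limit rather than a number is likely.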

Compound 4, half-maximal inhibitory concentration: > 50000 nM
Compound 4 gave a limit, no number (the forecaster's own chance of this, stated with the estimate: 80%); the middle value does not contradict the limit.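

In this assay compound 4 gives only a limit, > 50000 nM, and no number. Putting 3-(trifluoromethyl)phenyl in place of 2-(trifluoromethyl)phenyl gives an at least 3.0-fold higher number from compound 3 to compound 4 (0.48 log units; beyond the scatter), so on this second core the change again leads to a weaker result, beyond the usual scatter, and its direction carries over between the two cores shown: the same change on two cores in this assay, an at least 8.6-fold higher number (0.93 log units; beyond the scatter) from compound 1 to compound 2 and an at least 3.0-fold higher number (0.48 log units; beyond the scatter) from compound 3 to compound 4; the limit leaves it open whether they differ The size of the change on either core stays unknown, so these compounds do not show that it carries over with the same strength, and the step between compound 2 and compound 4 cannot be read, since both compounds sit at one limit: the limit of > 50000 nM in this assay, at which 2 of the 4 values shown sit.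

The compounds shown leave open whether the same change would also weaken a core carrying two 4-hydroxyphenyl groups, since only cores with at least one 2-hydroxyphenyl group appear here. They also leave open what would happen if the trifluoromethyl group on this phenyl ring gave way to a different group, such as an amine or a carboxylic acid, and whether such a compound would give a readable number rather than a limit.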